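A Methyl on the Chain: From Compound 2 to Compound 3

The compounds below may be only part of what the source reports. "The series", "measured", "known", "first", "only" and "open" are said of these compounds alone.

Compound 1 `Clc1ccc2cc(NCCCCNc3nc(Nc4ccccc4)nc(Nc4ccccc4)n3)cnc2c1` in an ADME assay on HepG2 cells (Homo sapiens) for cytotoxicity; on this read-out higher numbers stand for weaker inhibition and lower numbers for stronger inhibition: 9800 nM
Compound 2 `Cc1ccccc1Nc1nc(NCCNc2cnc3cc(Cl)ccc3c2)nc(Nc2ccccc2C)n1` in this assay: 9800 nM

Of the compounds shown here, two have been measured in this assay so far. Compound 1 gives 9800 nM in this assay, and compound 2 gives 9800 nM in the same test. On the digits shown, compound 2 stands level with compound 1; the two values lie within the usual scatter of this kind of measurement, so no difference between them can be claimed.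

Compound 3 `Cc1ccccc1Nc1nc(Nc2ccccc2C)nc(NC(C)CNc2cnc3cc(Cl)ccc3c2)n1` has not been measured yet. It differs from compound 2 in one place: methyl in place of hydrogen on a saturated chain carbon bound to a nitrogen on an aromatic ring and a saturated chain carbon. The rest of the molecule stays as it is in compound 2.

For the measured compounds named here, no pair of measured compounds shows the effect of such a change, so there is no measured step to lean on. With only one heavy atom entering and no donor or acceptor added, the expected step is small in either direction, most likely none beyond the scatter. The step from compound 2 to compound 3 in this assay is therefore expected to be no change at the digits printed from compound 2 to compound 3 (within the scatter). For compound 3 the estimated value in this assay is 9800 nM, within a range from 4000 nM to 25000 nM.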

Compound 3, half-maximal inhibitory concentration: 8800 nM
The estimate for compound 3 lay 1.1-fold (0.05 log units) above the measured number; the measured number falls inside the stated range.
By their numbers in this assay, from the lowest: compounds 3, 1 and 2 (each within the scatter of the next).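

For the compounds shown here, the first change at a single place in this set can now be read: in this assay, methyl in place of hydrogen on a saturated chain carbon bound to a nitrogen on an aromatic ring and a saturated chain carbon gives a 1.1-fold lower number from compound 2 to compound 3 (0.05 log units; within the scatter) and no difference that can be claimed. At this position, then, one added carbon leaves the cell read-out indistinguishable from that of the unbranched chain, so this small branch can be carried on this chain without a detectable shift in this test. Nothing available here bears on why the number holds, and the result stands as an observation only.

The compounds shown leave open whether a larger or different group on the same carbon, such as ethyl, hydroxymethyl or an amine, would also leave the read-out in place. They also leave open whether methyl would read the same way on the chain of compound 1, since a single step on a single chain cannot establish a general rule.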